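This account rests on a few compounds, and the source may have more. Where it says the series, first, only, none or still open, it means among the compounds named here.

Of the compounds shown here, three sharing one core have been measured in a functional assay on DU-145 cells (Homo sapiens) for cytotoxicity, read by trypan blue exclusion, with a stated time of 96 h; a higher number here means a weaker inhibitor, a lower number a stronger inhibitor. Compound 1 `COc1cc(OC)c(/C=C/S(=O)(=O)Cc2ccc(OC)c([N+](=O)[O-])c2)c(OC)c1` gives 2500 nM and compound 2 `COc1ccc(CS(=O)(=O)/C=C/c2cc(OC)c(OC)c(OC)c2)cc1N` gives 3000 nM, two values within the scatter of each other. Compound 3 `COC(=O)CNc1cc(CS(=O)(=O)/C=C/c2cc(OC)c(OC)c(OC)c2)ccc1OC` stands at 75000 nM, the highest number of the three and well beyond the scatter from both others.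

Compound 4 `COc1ccc(CS(=O)(=O)/C=C/c2cc(OC)c(OC)c(OC)c2)cc1NCC(=O)O` differs from compound 3 by one small change, hydrogen in place of methyl on an oxygen next to a carbonyl group, which turns (methoxycarbonyl)methyl into carboxymethyl.

Among the measured compounds shown here, only one measured step bears on this: a 25-fold higher number from compound 2 to compound 3 (1.40 log units; beyond the scatter), a large rise on attaching (methoxycarbonyl)methyl. For the measured compounds named here, no measured pair shows the methoxy to hydroxy change itself, so the size of the next step is poorly constrained. The expectation is a moderate fall in this assay that recovers only part of that large rise, with a step within the scatter also possible. Compound 4 is estimated at 25000 nM, within a range of 5000 nM to 100000 nM, an expected 3.0-fold lower number from compound 3 to compound 4 (0.48 log units; beyond the scatter).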

Compound 4, half-maximal inhibitory concentration: 5000 nM
Beside the measured number, compound 4's estimate is 5.0-fold (0.70 log units) above it; the measured number falls inside the stated range.
By their numbers in this assay, from the lowest: compounds 1, 2 and 4 (each within the scatter of the next); then compound 3.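

In this assay, hydrogen in place of methyl on an oxygen next to a carbonyl group gives a large step (a 15-fold lower number from compound 3 to compound 4 (1.18 log units; beyond the scatter)), so the high number of compound 3 goes with (methoxycarbonyl)methyl and not with every substituent on this nitrogen. Carboxymethyl on the same nitrogen stays within the scatter of hydrogen there (a 1.7-fold higher number from compound 2 to compound 4 (0.22 log units; within the scatter)), which means that, of the two substituents shown, only (methoxycarbonyl)methyl separates from hydrogen at this position. No measurement shown here gives a reason for this difference between the two substituents.

The compounds shown leave open whether an amide in place of the carboxylic acid would stay with compound 4 or move towards compound 3. They also leave open how a longer chain, such as carboxyethyl, would behave on this nitrogen.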